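The compounds below may be only part of what the source reports. "The series", "measured", "known", "first", "only" and "open" are said of these compounds alone.

Of the compounds shown here, three sharing one core have been tested in a functional assay on MOLT-4 cells (Homo sapiens) for inhibition, read by sulforhodamine B assay, with a stated time of 48 h, tested at 10 uM; on this read-out higher numbers stand for more inhibition of growth at the one concentration tested and lower numbers for less inhibition of growth. Compound 1, `CC(=O)c1cccc(Nc2ccnc(SCC(=O)c3ccc(-c4ccccc4)cc3)n2)c1`, gives 29%. Compound 3, `CC(=O)c1ccc(Nc2ccnc(SCC(=O)c3ccc(Br)cc3)n2)cc1`, gives 39%. Compound 2, `CCOC(=O)c1ccc(Nc2ccnc(SCC(=O)c3ccc([N+](=O)[O-])cc3)n2)cc1`, gives 58%, the highest of the three numbers; its gap to compound 3 and its gap to compound 1 both lie beyond the scatter of repeat measurements, so among these three compound 2 is the most active. Compound 4, `CCOC(=O)c1ccc(Nc2ccnc(SCC(=O)c3ccc(C#N)cc3)n2)cc1`, has not yet been measured in this assay. It differs from compound 2 in one place: cyano in place of nitro on an aromatic carbon. Within the data shown here, the three measured compounds differ from one another in more than one place, so no single-change step between them is available, and nothing in the data shows what a change at this position does on its own. For compound 4 the expected step of a number 8 percentage points lower from compound 2 to compound 4 (within the scatter) is a small one downward, of a size that may not clear the scatter. Compound 4 is estimated to give 50% in this assay, with a range from 30% to 70%.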

Compound 4, percent growth inhibition at one concentration: 84%
Compound 4: the middle estimate sits 34 percentage points below what was measured; measured number above the stated range.
By their numbers in this assay, from the lowest: compounds 1 and 3 (each within the scatter of the next); then compound 2; then compound 4.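

Among these compounds, the pair gives the first single-change reading at this position: with everything else in compound 2 kept, going from 4-nitrophenyl to 4-cyanophenyl raises the number in this assay by a modest step, a number 26 percentage points higher from compound 2 to compound 4 (beyond the scatter) and so clears the usual scatter. Among the compounds shown here, the aromatic carbon para to a large group is therefore a place where this one exchange alone shifts growth inhibition, and it shifts it upward, something the earlier compounds, each differing in more than one place, could not show. Nothing at hand accounts for the direction or size of this step.

What the compounds shown leave open is how other groups at this same carbon would compare with cyano and nitro, for instance an amine, a carboxylic acid or a methoxy group. On these data alone, it is also open whether cyano in place of nitro would give a similar step on a different background, such as the rest of compound 1 or compound 3, since this single pair speaks only for the ethyl ester series.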